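Chloro for methyl: from compound 3 to compound 4

This account rests on a few compounds, and the source may have more. Where it says the series, first, only, none or still open, it means among the compounds named here.

Measured so far in an ADME assay on Vero 76 cells (Chlorocebus sabaeus) for cytotoxicity, read by MTT assay, with a stated time of 96 h; a higher number here means that more compound is tolerated, a lower number that less compound is tolerated
- compound 1 `NS(=O)(=O)c1ccc(N2N=C(c3ccc(OCc4ccccc4)cc3)CC2c2ccccc2Cl)cc1` gives 92000 nM
- compound 2 `NS(=O)(=O)c1ccc(N2N=C(c3ccc(OCc4ccccc4)cc3)CC2c2ccc(Cl)cc2)cc1` gives 82000 nM
- compound 3 `Cc1cccc(C2CC(c3ccc(OCc4ccccc4)cc3)=NN2c2ccc(S(N)(=O)=O)cc2)c1` gives 100000 nM

Compound 3 stands at 100000 nM and cannot be separated from the other two compounds. The steps that reach it are a 1.1-fold higher number from compound 1 to compound 3 (0.04 log units; within the scatter) and a 1.2-fold higher number from compound 2 to compound 3 (0.09 log units; within the scatter). The remaining pair shows the same picture, with a 1.1-fold lower number from compound 1 to compound 2 (0.05 log units; within the scatter).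

The next compound to read is compound 4 `NS(=O)(=O)c1ccc(N2N=C(c3ccc(OCc4ccccc4)cc3)CC2c2cccc(Cl)c2)cc1`, which has chloro in place of methyl on an aromatic carbon, meta to a large group (chloro in place of methyl on an aromatic carbon). The same difference reads 3-methylphenyl to 3-chlorophenyl. Within the data shown here, no measured pair makes exactly this exchange, so the evidence is indirect. The closest steps also exchange a chlorine-bearing ring for the 3-methylphenyl ring, and they are small: a 1.1-fold higher number from compound 1 to compound 3 (0.04 log units; within the scatter) and a 1.2-fold higher number from compound 2 to compound 3 (0.09 log units; within the scatter). Moving the chlorine gave a 1.1-fold lower number from compound 1 to compound 2 (0.05 log units; within the scatter). All three measured compounds therefore sit together in this assay, and none of them goes against this, although three compounds are a narrow basis.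

No step beyond the scatter is expected, and the estimated step is a 1.1-fold lower number from compound 3 to compound 4 (0.05 log units; within the scatter). Compound 4 is expected at 90000 nM, with an estimated range of 60000 nM to 125000 nM.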

Compound 4, half-maximal cytotoxic concentration: 85000 nM
Compound 4: the middle estimate sits 1.1-fold (0.02 log units) above what was measured, and the stated range covers the measured number.
By their numbers in this assay, from the lowest: compounds 2, 4, 1 and 3 (each within the scatter of the next).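

In this assay, the direct exchange of chloro for methyl on an aromatic carbon, meta to a large group, gives a 1.2-fold lower number from compound 3 to compound 4 (0.07 log units; within the scatter), so this position now has a matched pair and the two groups cannot be separated there. With the 3-chlorophenyl compound in hand, the chlorine has been read in three placements on this ring: 3-chlorophenyl in place of 4-chlorophenyl gives a 1.0-fold higher number from compound 2 to compound 4 (0.02 log units; within the scatter), and 3-chlorophenyl in place of 2-chlorophenyl gives a 1.1-fold lower number from compound 1 to compound 4 (0.03 log units; within the scatter), so chlorine placement does not separate these compounds either. Nothing available explains why these compounds read alike.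

Going by these compounds, all four compounds carry only a chloro or a methyl group on this ring, so it remains open whether an amine, a carboxylic acid or a longer chain at the same place would also stay within the scatter. On these data alone, it is also open whether this flat reading would hold for these ring exchanges on a changed version of the shared core.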